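The source may hold more compounds than are shown below. What is called first, only, known or untested is meant among the compounds shown, and "the series" means these compounds.

Compound 3 `Cc1cc(NC(=O)COc2ccc3cc(/C=C4/SC(=O)NC4=O)ccc3c2)no1` carries a 5-methyl-1,2-oxazol-3-yl group on the amide nitrogen of a core it shares with two measured partners. In an assay on isolated protein for inhibition of histone deacetylase 8 (Homo sapiens), with a stated time of 1 h (a lower number here means a stronger inhibitor, a higher number a weaker inhibitor), compound 3 gives only a limit, > 50000 nM, and no number. Compound 1 `O=C(COc1ccc2cc(/C=C3/SC(=O)NC3=O)ccc2c1)Nc1cc(Cl)cc(C(F)(F)F)c1` likewise reaches only a limit in this assay, > 50000 nM. Compound 2 `Cc1cccc(NC(=O)COc2ccc3cc(/C=C4/SC(=O)NC4=O)ccc3c2)n1`, by contrast, gives a number in this assay, 7500 nM. The step of an at least 6.6-fold lower number from compound 1 to compound 2 (0.82 log units; beyond the scatter) and the step of an at least 6.6-fold higher number from compound 2 to compound 3 (0.82 log units; beyond the scatter) are both readable, whereas a step that the two limits leave unreadable from compound 1 to compound 3 cannot be sized, because of the limit of > 50000 nM in this assay, at which 2 of the 3 values shown sit.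

Compound 4 `O=C(COc1ccc2cc(/C=C3/SC(=O)NC3=O)ccc2c1)Nc1ccc(F)cc1F` differs from compound 3 in one place, (2,4-difluorophenyl in place of 5-methyl-1,2-oxazol-3-yl on an amide-type nitrogen). Going by the values given here, no measured step covers this exact exchange. Among the compounds with values here, the closest point of comparison is compound 1, which also bears a halogenated phenyl group on the amide nitrogen and sits at the limit, while the only group that gave a number was the 6-methylpyridin-2-yl of compound 2. A step of a number no higher from compound 3 to compound 4 (the limit leaves the size open) is therefore expected, that is, little or no change beyond the scatter. Compound 4 is expected to give about 50000 nM in this assay, within a range from 12000 nM to 200000 nM, with a real chance that only a limit is reported again.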

Compound 4, half-maximal inhibitory concentration: > 50000 nM
Compound 4: no number, only a limit; the forecaster's own chance of this, stated with the estimate: 60%; the middle value sits exactly at the limit.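

Compound 4 gives only a limit in this assay, which makes 2,4-difluorophenyl the third group on the amide nitrogen to end at that limit, and the second halogenated phenyl group to do so after the 3-chloro-5-(trifluoromethyl)phenyl of compound 1. Against the 6-methylpyridin-2-yl group, the change to 2,4-difluorophenyl gives an at least 6.6-fold higher number from compound 2 to compound 4 (0.82 log units; beyond the scatter), so among the four compounds shown, the 6-methylpyridin-2-yl group of compound 2 remains the only amide substituent that yields a number. The steps that link compound 4 to compound 1 and to compound 3 cannot be read, and the three groups cannot be ranked against each other, because of this shared ceiling: the limit of > 50000 nM in this assay, at which 3 of the 4 values shown sit.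

The compounds shown leave open whether the number for compound 2 depends on the ring nitrogen or on the methyl group of its 6-methylpyridin-2-yl, which a plain pyridin-2-yl group on the same amide nitrogen would help to separate. On these data alone, it also remains open how far past the limit compound 1, compound 3 and compound 4 lie, and whether any of them differ at all.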